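One Side Chain Swapped, With a Single Number to Lean On

A few compounds are considered here, and "the series" means these few. Any claim that something is new, unique, unknown or untested is made for them only; others in the source may bear on it.

Among the measured compounds shown here, only one compound in this small series has a measured result so far. In a functional assay on MOLT-4 cells (Homo sapiens) for inhibition, read by MTT assay, with a stated time of 48 h (on this read-out higher numbers stand for weaker inhibition and lower numbers for stronger inhibition), the entry for compound 1 `C=C(C)Cn1cc(/C=C/C(=O)CC(=O)C(=O)OCC)c2ccccc21` reads "not determined" (no result reported), and the entry for compound 2 `CCOC(=O)C(=O)CC(=O)/C=C/c1cn(-c2ccc(O)cc2)c2ccccc12` also reads "not determined" (no result reported). Compound 3 `C=C(C)Cn1cc(/C=C/C(=O)CC(=O)C(=O)O)c2ccccc21` gives 40000 nM. For the measured compounds named here, as this is the only number available, compound 3 cannot yet be ranked against anything, and it serves only as a reference point.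

The next compound to be tested is compound 4 `CN(C)C(=O)Cn1cc(/C=C/C(=O)CC(=O)C(=O)O)c2ccccc21`. It keeps the shared core of compound 3, but dimethylcarbamoyl takes the place of 1-methylethenyl on a saturated chain carbon bound to an aromatic nitrogen: dimethylcarbamoyl in place of 1-methylethenyl on a saturated chain carbon bound to an aromatic nitrogen.

Going by the values given here, no pair of measured compounds shows how much a change like this matters in this assay, so the data favour neither a rise nor a fall. With compound 3 at 40000 nM as the only anchor, the expectation stays close to that value. The estimated 1.1-fold higher number from compound 3 to compound 4 (0.05 log units; within the scatter) is no larger than the usual scatter of repeated measurements, and no direction is favoured. The range is kept wide, as a single value offers little guidance. For compound 4 the expected value is 45000 nM, within an estimated range from 15000 nM to 120000 nM.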

Compound 4, half-maximal inhibitory concentration: > 40000 nM
Compound 4: only a limit was reported; the forecaster's own chance of this, stated with the estimate: 25%; the middle value is on the limit's open side.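

In this assay, among the compounds shown here, the first readable step comes from the single side chain that differs between the two compounds: a number no lower from compound 3 to compound 4 (the limit leaves the size open). Lower numbers stand for stronger inhibition here, so this change brought no gain in inhibition, which a single measured compound could not show. Whether the number truly rose, and by how much, stays unknown because the result for compound 4 is a limit and not a number: the limit of > 40000 nM in this assay, at which 1 of the 4 values shown sits.

As far as these compounds go, with only these two side chains giving a result, it remains open whether any group at this place can bring the number down. An amine or a longer chain on the same saturated carbon would show whether inhibition in these cells responds to this position at all.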